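Swapping an alkyl tail for a dimethylamino group

The source may report more compounds than this note shows. Statements on the series, on what has been measured and on what is new or still open speak of the compounds shown alone.

Measured in a functional assay on PC-3 cells (Homo sapiens) for antiproliferative activity, read by MTT assay, with a stated time of 72 h; on this read-out higher numbers stand for weaker inhibition and lower numbers for stronger inhibition:
compound 1, `CC/C=C/C(=O)Nc1cc2c(N3CCc4ccccc43)ncnc2cc1O[C@@H]1CCOC1`, gives 9590 nM.
compound 2, `CC(C)/C=C/C(=O)Nc1cc2c(N3CCc4ccccc43)ncnc2cc1O[C@@H]1CCOC1`, gives 11200 nM.
compound 3, `CCC/C=C/C(=O)Nc1cc2c(N3CCc4ccccc43)ncnc2cc1O[C@@H]1CCOC1`, gives 9230 nM.

Compound 3 sits alongside the other two: the step of a 1.0-fold lower number from compound 1 to compound 3 (0.02 log units; within the scatter) and the step of a 1.2-fold lower number from compound 2 to compound 3 (0.08 log units; within the scatter) both lie within the scatter, as does a 1.2-fold higher number from compound 1 to compound 2 (0.07 log units; within the scatter). Compound 4, `CN(C)C/C=C/C(=O)Nc1cc2c(N3CCc4ccccc43)ncnc2cc1O[C@@H]1CCOC1`, differs from compound 3 by dimethylamino in place of ethyl on a saturated chain carbon bound to a double-bonded chain carbon. The three measured steps each exchange one small alkyl piece for another on the chain, and none shifts this assay beyond the scatter. For the measured compounds named here, no measured step exchanges an alkyl piece for an amine, so these steps bear only loosely on the present change. Compound 4 is therefore expected to show no step beyond the scatter, though with a wide margin, and is estimated at 9000 nM in this assay, within 2500 nM to 32000 nM, an expected step of a 1.0-fold lower number from compound 3 to compound 4 (0.01 log units; within the scatter).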

Compound 4, half-maximal inhibitory concentration: 1230 nM
For compound 4 the middle estimate is 7.3-fold (0.86 log units) above the measured one; measured number outside the range, below it.
By their numbers in this assay, from the lowest: compound 4; then compounds 3, 1 and 2 (each within the scatter of the next).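

Small alkyl exchanges on this chain left this assay within the scatter, but dimethylamino in place of ethyl gives a 7.5-fold lower number from compound 3 to compound 4 (0.88 log units; beyond the scatter) and moves the number beyond it. The other two alkyl compounds show the same direction, with a 7.8-fold lower number from compound 1 to compound 4 (0.89 log units; beyond the scatter) and a 9.1-fold lower number from compound 2 to compound 4 (0.96 log units; beyond the scatter) both beyond the scatter. Nothing shown here explains the change.

Open, on these data alone, is whether the nitrogen itself matters, which an isopropyl group on the same saturated chain carbon would test. Also open, as far as these compounds go, is how other amines, such as piperidine or morpholine, compare there.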